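The source may hold more compounds than are shown below. What is called first, only, known or untested is meant among the compounds shown, and "the series" means these compounds.

Working notes on the series around compound 1 `CCCCC(O)CC(=O)O[C@H](CC=C(C)C)C1=CC(=O)c2c(O)ccc(O)c2C1=O`. Among the measured compounds shown here, in a functional assay on HeLa cells (Homo sapiens) for cytotoxicity, read by MTT assay (on this read-out lower numbers stand for stronger inhibition and higher numbers for weaker inhibition), compound 1 gives 72200 nM, the highest of the three numbers so far. Compound 2 `CCC(O)CO[C@H](CC=C(C)C)C1=CC(=O)c2c(O)ccc(O)c2C1=O` gives 28700 nM in this assay, and compound 3 `CC(C)=CC[C@@H](OC(=O)CC(O)c1ccccc1)C1=CC(=O)c2c(O)ccc(O)c2C1=O` gives 44500 nM. The step from compound 1 to compound 2 is a 2.5-fold lower number from compound 1 to compound 2 (0.40 log units; beyond the scatter), where a 2-hydroxybutyl replaces the (2-hydroxyhexyl)carbonyl on the oxygen. The step from compound 1 to compound 3 is a 1.6-fold lower number from compound 1 to compound 3 (0.21 log units; within the scatter), where the change sits on the saturated chain carbon bearing the hydroxyl.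

The next compound, compound 4 `CCC(O)(CC)CC(=O)O[C@H](CC=C(C)C)C1=CC(=O)c2c(O)ccc(O)c2C1=O`, differs from compound 1 by 1-ethyl-1-hydroxypropyl in place of 1-hydroxypentyl on a saturated chain carbon bound to a carbonyl carbon; the two have the same atoms, joined differently. For the measured compounds named here, of the measured steps, the one from compound 1 to compound 3 is the closer relative, since it also alters the hydroxyl-bearing carbon of the acyl chain while keeping the ester; that step stayed within the scatter. The step from compound 1 to compound 2 changed the linkage itself and bears less on this case. The expectation is therefore a step of about a 1.2-fold lower number from compound 1 to compound 4 (0.08 log units; within the scatter) in this assay, that is, nothing clearly beyond the scatter. Compound 4 is estimated at 60000 nM, with a likely range from 25000 nM to 150000 nM.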

Compound 4, half-maximal inhibitory concentration: 52000 nM
The estimate for compound 4 lay 1.2-fold (0.06 log units) above the measured number; low and high end bracket the measured number.
By their numbers in this assay, from the lowest: compounds 2, 3, 4 and 1 (each within the scatter of the next, the first and the last beyond it).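

In this assay, the isomeric exchange of 1-hydroxypentyl for 1-ethyl-1-hydroxypropyl on the saturated chain carbon bound to a carbonyl carbon gives a 1.4-fold lower number from compound 1 to compound 4 (0.14 log units; within the scatter) and so leaves the number unresolved from that of compound 1, while the exchange of hydroxy(phenyl)methyl for the same group gives a 1.2-fold higher number from compound 3 to compound 4 (0.07 log units; within the scatter) and likewise stays unresolved. The linkage change also reads differently here: a 2.5-fold lower number from compound 1 to compound 2 (0.40 log units; beyond the scatter) stood beyond the scatter, but a 1.8-fold higher number from compound 2 to compound 4 (0.26 log units; within the scatter) does not, so the separation seen for compound 2 holds against compound 1 and not against compound 4. No supporting data accompany these numbers to account for any of these steps.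

Every compound shown keeps a hydroxyl on this side chain, so it remains open whether a plain pentyl group, with no hydroxyl, would give a number beyond the scatter of compound 1. It is also open whether an amine, a carboxylic acid or a longer chain at this position would shift the number clearly, since the groups shown so far give steps from compound 4 that all remain within the scatter.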